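Swapping the Anilino Group of Compound 1 for a Piperazine

The source may report more compounds than this note shows. Statements on the series, on what has been measured and on what is new or still open speak of the compounds shown alone.

Of the compounds shown here, three with a shared core have been measured in a functional assay on HepG2 cells (Homo sapiens) for antiproliferative activity, read by CCK-8 assay, with a stated time of 72 h, tested at 2 uM; a lower number here means a weaker effect, a higher number a stronger effect of the compound at the concentration tested. Compound 1 `Cc1ccc(Nc2nc(Cl)nc3c2ncn3Cc2ccc(C(=O)Nc3ccccc3N)cc2)cc1` gives 76.2%, the highest of the three numbers. Compound 3 `CCCCn1cnc2c(Nc3ccccc3)nc(NCOCc3ccc(C(=O)Nc4ccccc4N)cc3)nc21` gives 46.6%, and compound 2 `Cc1ccc(Nc2nc(Cl)nc3c2ncn3Cc2ccc(/C=C/C(=O)Nc3ccccc3N)cc2)cc1` gives 33.6%. Among the compounds with values here, the one step between compounds that differ in a single place runs a number 42.6 percentage points lower from compound 1 to compound 2 (beyond the scatter); it concerns the amide-bearing arm and not the part of the core changed here. Compound 3 differs from compound 1 in several places at once, so its gap to compound 1 cannot be tied to one change.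

Compound 4 `CN1CCN(c2nc(Cl)nc3c2ncn3Cc2ccc(C(=O)Nc3ccccc3N)cc2)CC1` is the compound still to be measured. It differs from compound 1 as follows: 4-methylpiperazin-1-yl in place of (4-methylphenyl)amino on an aromatic carbon. Within the data shown here, no measured step touches this position, so the expectation rests on compound 1 alone. A large change in size cannot be ruled out in either direction, but with nothing to point one way, the central estimate stays near compound 1 and is only modestly lower, with a wide range. Compound 4 is estimated to give 58%, between 25% and 82%. The expected step is therefore a number 18.2 percentage points lower from compound 1 to compound 4 (beyond the scatter).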

Compound 4, a percentage reported as inhibition, at one concentration (the size of the read-out at that concentration, not a potency): 60.4%
Compound 4: middle estimate off by 2.4 percentage points, on the low side; the measured number falls inside the stated range.
By their numbers in this assay, from the lowest: compound 2; then compound 3; then compound 4; then compound 1.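

In this assay, putting 4-methylpiperazin-1-yl in place of (4-methylphenyl)amino on this aromatic carbon gives a number 15.8 percentage points lower from compound 1 to compound 4 (beyond the scatter), the first step seen at this position. The position therefore responds to what it carries, yet the effect survives without an aromatic ring of carbon only or a hydrogen-bond donor in this group, with compound 4 still giving 60.4%. Nothing available here explains the size of this step.

This single swap changes the ring type and the counts of donors and acceptors together, so it cannot show which of these differences matters, and a cyclohexylamino group, which keeps the amino hydrogen on a non-aromatic ring, would help to pull them apart. A morpholin-4-yl group, with a ring oxygen in place of the methyl-bearing nitrogen, would likewise test whether that part of the piperazine matters, while the open question for the aromatic side is how a plain anilino group or a 4-methoxyphenylamino group would compare with the (4-methylphenyl)amino group of compound 1.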